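The source may report more compounds than this note shows. Statements on the series, on what has been measured and on what is new or still open speak of the compounds shown alone.

Measured so far:
compound 1 `CN(Cc1ccc(OCCCNC(=N)N)cc1)c1nc2ccc(Oc3cccc(C(F)(F)F)c3)cc2s1`, > 24 h in an ADME assay on a cell-free system (plasma, Rattus norvegicus) for metabolic stability; a lower number here means that the compound disappears faster, a higher number that the compound lasts longer
compound 2 `N=C(N)NCCCOc1ccc(CNc2nc3ccc(Oc4ccc(C(F)(F)F)cc4)cc3s2)cc1`, > 24 h

Compound 1 carries a guanidine group on the end of its side chain, and in this assay compound 1 gives only a limit, > 24 h, not a number. Compound 2 likewise reaches a limit in this assay, > 24 h. For the measured compounds named here, both values therefore sit at the limit of > 24 h in this assay, at which 2 of the 2 values shown sit, so compound 1 stands exactly where the one other measured compound stands, and no order between them can be read.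

Compound 3 `CN(Cc1ccc(OCCCN)cc1)c1nc2ccc(Oc3cccc(C(F)(F)F)c3)cc2s1` differs from compound 1 in one place: a hydrogen atom in place of a group of 3 heavy atoms (1 carbon, 2 nitrogen; no ring), on an amine nitrogen. Going by the values given here, no measured pair shows what such a change does in this assay, so the step from compound 1 to compound 3 cannot be sized from data here; the expectation is no change beyond the scatter, as a number no higher from compound 1 to compound 3 (the limit leaves the size open). Compound 3 is thus expected to give 24 h, most likely again as a limit, within 8 h to 48 h.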

Compound 3, half-life: > 24 h
Compound 3: only a limit was reported; the forecaster's own chance of this, stated with the estimate: 65%; the middle value sits exactly at the limit.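

Compound 3, like compound 1, gives only a limit in this assay, not a number, so no step between the two can be read: the limit of > 24 h in this assay, at which 3 of the 3 values shown sit.

The compounds shown leave open how long each one really lasts in this assay, and whether putting a hydrogen atom on that amine nitrogen changes this at all.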